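The source may report more compounds than this note shows. Statements on the series, on what has been measured and on what is new or still open speak of the compounds shown alone.

Compound 3 `COc1cc(-c2nn(-c3cccc(NC(=O)Nc4ccc(Cl)c(Cl)c4)c3)cc2-c2ccncc2)ccc1Cl` stands only at a limit in a functional assay on Malme-3M cells (Homo sapiens) for inhibition, read by sulforhodamine B assay, with a stated time of 48 h; on this read-out lower numbers stand for higher toxicity in this test and higher numbers for lower toxicity in this test: in this assay compound 3 gives > 50000 nM, which is a limit of the assay and not a number. Compound 2 `COc1cc(-c2nn(-c3cccc(NC(=O)c4cccc(C(F)(F)F)c4)c3)cc2-c2ccncc2)ccc1Cl` likewise gives > 50000 nM in this assay, again a limit. The step that the two limits leave unreadable from compound 2 to compound 3 therefore cannot be read, because both values sit at the limit of > 50000 nM in this assay, at which 2 of the 3 values shown sit. Going by the values given here, compound 1 `COc1cc(-c2nn(-c3cccc(NC(=O)Nc4cc(C(F)(F)F)cc(C(F)(F)F)c4)c3)cc2-c2ccncc2)ccc1Cl` is the only member of the set with a number: in this assay compound 1 gives 7680 nM.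

Compound 4 `COc1cc(-c2nn(-c3cccc(NC(=O)Nc4cccc(C(F)(F)F)c4)c3)cc2-c2ccncc2)ccc1Cl` is reached from compound 3 by one change: 3-(trifluoromethyl)phenyl in place of 3,4-dichlorophenyl on an amide-type nitrogen. Among the compounds with values here, no measured step touches this exact exchange, and the one step that shares compound 3 is unreadable. Compound 1 and compound 4 both carry a urea with trifluoromethyl on the distal ring, so compound 1 marks where a number of this kind has been seen; compound 3 marks the limit. Compound 4 is therefore expected to fall between these, as a step of an at least 1.6-fold lower number from compound 3 to compound 4 (0.22 log units; that floor lies within the scatter) that may still end at the limit. The estimate for compound 4 in this assay is 30000 nM, within 8000 nM to 100000 nM.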

Compound 4, concentration lethal to 50% of the cells: 33900 nM
The estimate for compound 4 lay 1.1-fold (0.05 log units) below the measured number; the measured number falls inside the stated range.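

In this assay the exchange on the amide-type nitrogen gives an at least 1.4-fold lower number from compound 3 to compound 4 (0.16 log units; that floor lies within the scatter) and so brings a urea off the limit and onto a number. With 3-(trifluoromethyl)phenyl kept, the urea in place of the amide gives an at least 1.4-fold lower number from compound 2 to compound 4 (0.16 log units; that floor lies within the scatter) and, like the step before it, has a floor that lies within the scatter, so neither step alone establishes a change. Among the ureas, the loss of the second trifluoromethyl gives a 4.4-fold higher number from compound 1 to compound 4 (0.64 log units; beyond the scatter) and is the first step in this set whose size can be read, beyond the scatter.

On these data alone, compound 2 and compound 3 are limits of the assay, not numbers, and the full size of the two steps from them stays open: the limit of > 50000 nM in this assay, at which 2 of the 4 values shown sit. As far as these compounds go, whether a nitrile or a methoxy group in place of trifluoromethyl on the distal ring would keep a number in this test also stays open.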